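Amide nitrogen substituent changes on the shared core

This account rests on a few compounds, and the source may have more. Where it says the series, first, only, none or still open, it means among the compounds named here.

- compound 1 `COc1ccc(OC)c(-c2cc(-c3ccc(C(=O)N(C)C)s3)on2)c1`: in a functional assay on A549 cells (Homo sapiens) for cytotoxicity, read by XTT assay, with a stated time of 72 h (a lower number here means a stronger inhibitor, a higher number a weaker inhibitor), compound 1 gives > 30000 nM, a limit of the assay rather than a number.
- compound 2 `COc1ccc(OC)c(-c2cc(-c3ccc(C(=O)N(C)Cc4ccccc4)s3)on2)c1`: in this assay compound 2 gives > 30000 nM, again a limit.
- compound 3 `COc1ccc(CN(C)C(=O)c2ccc(-c3cc(-c4cc(OC)ccc4OC)no3)s2)cc1`: in this assay compound 3 gives > 30000 nM, also a limit.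

All three measured compounds sit at the same limit (the limit of > 30000 nM in this assay, at which 3 of the 3 values shown sit). The steps among them, a step that the two limits leave unreadable from compound 1 to compound 2, a step that the two limits leave unreadable from compound 1 to compound 3 and a step that the two limits leave unreadable from compound 2 to compound 3, cannot be sized. Compound 3 stands only at a limit, with no number beneath it, and the two further values shown beside it are limits as well.

Compound 4 `COc1ccc(OC)c(-c2cc(-c3ccc(C(=O)NC4CC4)s3)on2)c1` differs from compound 3 by cyclopropylamino in place of (4-methoxybenzyl)(methyl)amino on a carbonyl carbon. For the measured compounds named here, none of the measured steps touches the carbonyl carbon in this way; they exchange what sits on the amide-type nitrogen or put a methoxy in place of hydrogen on an aromatic carbon, and in every case the value stays at the limit, giving no readable size and no direction for this assay. No step beyond the scatter is therefore expected, and compound 4 is estimated to remain at or near the limit. The expected value for compound 4 is 30000 nM, within 10000 nM to 100000 nM. The step this estimate means is a number no higher from compound 3 to compound 4 (the limit leaves the size open), expected to lie within the scatter.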

Compound 4, half-maximal inhibitory concentration: > 30000 nM
Compound 4 was reported as a limit (the forecaster's own chance of this, stated with the estimate: 70%); the middle value sits exactly at the limit.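

In this assay compound 4 gives > 30000 nM, a limit. The steps to compound 4 from compound 1, compound 2 and compound 3 therefore cannot be read: the limit of > 30000 nM in this assay, at which 4 of the 4 values shown sit.

On these data alone, whether any amide substituent on the shared core gives a readable number in this assay remains open.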